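The source may report more compounds than this note shows. Statements on the series, on what has been measured and on what is new or still open speak of the compounds shown alone.

Of the compounds shown here, three have so far been tested in a functional assay on NCI-H226 cells (Homo sapiens) for inhibition, read by MTT assay, with a stated time of 48 h, tested at 10 uM; a lower number here means less inhibition, a higher number more inhibition at the concentration tested (going by the name of the read-out). Compound 1 `COc1cc(NC(=O)Nc2cc(Nc3cccc(C(C)(C)C)c3)ncn2)cc(OC)c1` gives 40% in this assay. Compound 2 `COc1cc(NC(=O)Nc2cc(Nc3cc(C(F)(F)F)ccc3OC)ncn2)cc(OC)c1` gives 60%, and compound 3 `COc1ccc(C(F)(F)F)cc1Nc1cc(NC(=O)Nc2c(Cl)cccc2Cl)ncn1` gives 60.1%. Compound 1 thus has the lowest of the three numbers, and its distance to compound 2 and to compound 3 lies beyond the usual scatter of repeated measurements, while the numbers of compound 2 and compound 3 lie within that scatter of each other.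

Compound 2 and compound 3 share a core and differ in one place: 2,6-dichlorophenyl in place of 3,5-dimethoxyphenyl on an amide-type nitrogen. That change made a step of a number 0.1 percentage points higher from compound 2 to compound 3 (within the scatter). How the core of compound 1 differs from the core of compound 2 is not broken down here, as the two differ in more than one place.

Compound 4 `CC(C)(C)c1cccc(Nc2cc(NC(=O)Nc3c(Cl)cccc3Cl)ncn2)c1` has not yet been measured. It carries the same change, made on compound 1 instead: 2,6-dichlorophenyl in place of 3,5-dimethoxyphenyl on an amide-type nitrogen. The place is the same in both pairs, an amide-type nitrogen whose other neighbour is a carbonyl carbon, so this is the same change rather than merely the same kind. Because the same change earlier gave a number 0.1 percentage points higher from compound 2 to compound 3 (within the scatter), the step is expected to be equally small, no change at the digits printed from compound 1 to compound 4 (within the scatter). For the measured compounds named here, only that one earlier pair shows this change, so the expectation rests on it alone. Compound 4 is therefore estimated to give about 40% in this assay, most likely between 25% and 55%.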

Compound 4, a percentage reported as inhibition, at one concentration (the size of the read-out at that concentration, not a potency): 36.5%
For compound 4 the middle estimate is 3.5 percentage points above the measured one; measured number inside the range.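

In this assay, 2,6-dichlorophenyl in place of 3,5-dimethoxyphenyl on the amide-type nitrogen gives a number 3.5 percentage points lower from compound 1 to compound 4 (within the scatter), so on the core of compound 1, as on the other core, the two groups cannot be told apart in this read-out. Set side by side, the two steps agree, which means that in this series the result of the change carries from one core to the other: the same change on two cores in this assay, a number 0.1 percentage points higher (within the scatter) from compound 2 to compound 3 and a number 3.5 percentage points lower (within the scatter) from compound 1 to compound 4, 3.6 percentage points apart, within the scatter of two such steps. This rests on just two cores and on a single read-out at one concentration, so it does not show that the two groups would match on other cores or at other concentrations, nor does it show why they match here.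

Both groups compared at this place are six-membered aromatic rings of carbon only, so the compounds shown leave open whether a group of another type, such as an amine, a carboxylic acid or a longer chain, would give a similar number on the amide-type nitrogen. They also leave open how either core would respond to a ring carrying other substituents, for example a nitrile or a single fluorine.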